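This account rests on a few compounds, and the source may have more. Where it says the series, first, only, none or still open, it means among the compounds named here.

Of the compounds shown here, three built on one shared core have been tested in a functional assay on the whole organism with Mus musculus as the target, with a stated time of 0.5 h; a higher number here means that more compound is needed for the effect, a lower number that less compound is needed. Compound 1 `O=C(CCC(=O)c1ccccc1)Nc1nc2ccc(Cl)cc2s1` gives 300 mg/kg. Compound 2 `Cc1ccc2nc(NC(=O)CCC(=O)c3ccccc3)sc2c1` gives 300 mg/kg, and the step of no change at the digits printed from compound 1 to compound 2 (within the scatter) stays within the scatter. Compound 3 `Cc1ccc2nc(NC(=O)c3ccccc3C(=O)c3ccccc3)sc2c1` gives 300 mg/kg, level with compound 1 and compound 2 within the scatter, so all three read the same at the digits shown.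

Compound 4 `COc1ccc2nc(NC(=O)c3ccccc3C(=O)c3ccccc3)sc2c1` carries a single change relative to compound 3: methoxy in place of methyl on an aromatic carbon. Within the data shown here, no measured step swaps methyl for methoxy, so there is no direct precedent. Among the measured compounds shown here, the only step available, no change at the digits printed from compound 1 to compound 2 (within the scatter), also exchanges one small group for another on an aromatic carbon of the same core and shows no change beyond the scatter; it is the nearest guidance. The step from compound 3 to compound 4 is therefore expected to be no change at the digits printed from compound 3 to compound 4 (within the scatter), that is, nothing beyond the scatter. The estimate for compound 4 in this assay is 300 mg/kg, with a range from 150 mg/kg to 600 mg/kg.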

Compound 4, minimum effective dose: 300 mg/kg
Estimate against measurement, compound 4: no gap at the digits printed; the range from low to high includes it.
By their numbers in this assay, from the lowest: compounds 1, 2, 3 and 4 (each within the scatter of the next).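

In this assay, methoxy in place of methyl gives no change at the digits printed from compound 3 to compound 4 (within the scatter), so adding a hydrogen-bond acceptor and one more heavy atom on this aromatic carbon leaves the reading where it was. Together with the earlier step, no change at the digits printed from compound 1 to compound 2 (within the scatter), this shows the same carbon carrying chloro, methyl and methoxy, with the two swaps, each made on a different side chain, both staying within the scatter. Nothing available gives a reason for this flat result.

All four compounds read alike, so the shared core and its substituents do not yet show what would lower the dose needed. As far as these compounds go, whether an amine or a carboxylic acid on this carbon, or a longer chain such as ethoxy, would move the number remains open.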